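Methyl on the pendant phenyl of compound 3

The compounds below may be only part of what the source reports. "The series", "measured", "known", "first", "only" and "open" are said of these compounds alone.

Of the compounds shown here, three of a shared core have been measured in a functional assay on MDA-MB-231 cells (Homo sapiens) for antiproliferative activity, with a stated time of 72 h; on this read-out higher numbers stand for weaker inhibition and lower numbers for stronger inhibition. Compound 1 `Cc1ccc(C2=NN(c3nc(-c4ccccc4)c(C#N)c(=O)n3C)C(c3ccc(F)cc3)C2)cc1` gives 5100 nM. Compound 2 `COc1ccc(C2CC(c3ccccc3)=NN2c2nc(-c3ccc(Cl)cc3)c(C#N)c(=O)n2C)cc1` gives 19500 nM, and compound 3 `Cn1c(N2N=C(c3ccccc3)CC2c2ccc(F)cc2)nc(-c2ccc(Cl)cc2)c(C#N)c1=O` gives 20900 nM, the highest of the three numbers, though the gap a 1.1-fold higher number from compound 2 to compound 3 (0.03 log units; within the scatter) is within the scatter. For the measured compounds named here, the only single-point step recorded, fluoro in place of methoxy from compound 2 to compound 3, does not touch the change now at hand.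

Compound 4 `Cc1ccc(C2=NN(c3nc(-c4ccc(Cl)cc4)c(C#N)c(=O)n3C)C(c3ccc(F)cc3)C2)cc1` differs from compound 3 by methyl in place of hydrogen on an aromatic carbon. Going by the values given here, no measured pair isolates this change. Compound 1, which carries the same 4-methylphenyl but lacks the chloro on the other aryl, sits at a lower number than compound 3, yet two differences separate them, so that gap cannot be attributed to the methyl alone. The expected step of a 1.6-fold lower number from compound 3 to compound 4 (0.21 log units; within the scatter) is therefore a small one toward a lower number, of a size that may not clear the scatter. Compound 4 is expected to give about 13000 nM, within a range from 5000 nM to 32000 nM.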

Compound 4, half-maximal inhibitory concentration: 19300 nM
Estimate against measurement, compound 4: 1.5-fold (0.17 log units) below; the measured number falls inside the stated range.
By their numbers in this assay, from the lowest: compound 1; then compounds 4, 2 and 3 (each within the scatter of the next).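

In this assay the step of a 1.1-fold lower number from compound 3 to compound 4 (0.03 log units; within the scatter) shows that methyl in place of hydrogen, para to a large group on the pendant phenyl, makes no readable difference when the chloro is present. The step of a 3.8-fold higher number from compound 1 to compound 4 (0.58 log units; beyond the scatter) holds the 4-methylphenyl fixed and isolates the added chloro, so the lower number of compound 1 goes with the absent chloro and not with the methyl. No measurement at hand explains either step.

The compounds shown leave open whether the methyl step would read the same on a core without the chloro. They also leave open whether an amine or a carboxylic acid at this place on the phenyl would move the number beyond the scatter.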